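The source may hold more compounds than are shown below. What is called first, only, known or untested is meant among the compounds shown, and "the series" means these compounds.

Compound 1 `C[C@H](NCc1ccc(OCc2cccc(F)c2)cc1C1CC1)C(N)=O` was tested in an assay on Sf9 cells for inhibition of Amine oxidase [flavin-containing] A (Homo sapiens), with stated times of 15 min and 60 min (on this read-out higher numbers stand for weaker inhibition and lower numbers for stronger inhibition), where compound 1 gives 75200 nM, the highest of the two numbers in hand. Its nearest neighbour is compound 2 `CC1(C)C[C@@H](C(N)=O)N(Cc2ccc(OCc3cccc(F)c3)cc2)C1`, which in this assay gives 17500 nM, a gap beyond the usual scatter. Compound 3 `C[C@H](NCc1ccc(OCc2cccc(F)c2)cc1Cl)C(N)=O` differs from compound 1 by a single change: chloro in place of cyclopropyl on an aromatic carbon. Among the measured compounds shown here, no measured pair shows this change, so there is nothing to lean on. The expected step is a 1.5-fold lower number from compound 1 to compound 3 (0.18 log units; within the scatter), small and at most slightly toward stronger inhibition. Compound 3 is therefore estimated at 50000 nM, within a range of 15000 nM to 150000 nM.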

Compound 3, half-maximal inhibitory concentration: 12000 nM
Estimate against measurement, compound 3: 4.2-fold (0.62 log units) above; measured number outside the range, below it.
By their numbers in this assay, from the lowest: compounds 3 and 2 (each within the scatter of the next); then compound 1.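

Chloro in place of cyclopropyl, on the aromatic carbon ortho to the ((1-carbamoylethyl)amino)methyl group, brings a 6.3-fold lower number from compound 1 to compound 3 (0.80 log units; beyond the scatter) in this assay and gives the first comparison of compounds that differ in one place. It shows that the group at this position alone can shift the result toward stronger inhibition, by more than the usual scatter. Nothing in the available data explains this step.

The compounds shown leave open whether other groups at this carbon, such as fluoro, methyl or methoxy, would give a similar shift. They also leave open whether the same change would have a similar effect on a different amide side chain.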